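A few compounds are considered here, and "the series" means these few. Any claim that something is new, unique, unknown or untested is made for them only; others in the source may bear on it.

In a functional assay for inhibition, with Homo sapiens as the target (on this read-out higher numbers stand for weaker inhibition and lower numbers for stronger inhibition), compound 2 `O=C(O)CCCCCCCCn1cc(-c2ccccc2)cn1` gives > 105000 nM, which is a limit of the assay and not a number. Compound 2 therefore has no measured potency, only a limit. The same holds for its relative compound 1 `O=C(O)CCCCCCCCn1nc(-c2ccccc2)cc1-c1ccccc1`, which carries a second phenyl group on the shared core and gives > 66000 nM, also a limit. Among the compounds with values here, neither compound yields a true number, so no measured step is available as a guide.

Compound 3 `O=C(O)CCCCCCCCn1cc(-c2ccccc2)c(-c2ccccc2)n1` is made from compound 2 by one change: phenyl in place of hydrogen on an aromatic carbon. In words, this is phenyl in place of hydrogen on an aromatic carbon, so compound 3 also carries a second phenyl group, though at a different place from compound 1. Compound 1, at > 66000 nM, shows that a second phenyl group on this core does not by itself guarantee a readable potency, so only a modest gain at best is expected in this assay. The expected step is an at least 1.7-fold lower number from compound 2 to compound 3 (0.24 log units; that floor lies within the scatter), and it may prove no larger than the scatter. For compound 3 the estimated value is 60000 nM, with an expected range from 15000 nM to 120000 nM.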

Compound 3, half-maximal inhibitory concentration: 4500 nM
Compound 3: the middle estimate sits 13-fold (1.12 log units) above what was measured; the whole stated range lies above it.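

Phenyl in place of hydrogen on an aromatic carbon, next to the ring nitrogen and next to the ring atom that bears a phenyl group, is the first change here to bring a readable number in this assay, with an at least 23-fold lower number from compound 2 to compound 3 (1.36 log units; beyond the scatter). Compound 1, which carries its second phenyl group at a different place on the shared core, gives > 66000 nM, a limit of the assay and not a number, so among these compounds a second phenyl group alone does not bring a readable number. Going by these compounds, the true size of the step stays unknown, because compound 2 has no number of its own: the limit of > 105000 nM in this assay, at which 1 of the 3 values shown sits.

The compounds shown do not tell whether a smaller group such as methyl or chlorine, or a different ring such as pyridine, would serve as well as phenyl at this position. Also open, on these data alone, is how compound 3 would respond to a shorter or longer chain on the ring nitrogen, or to an amide in place of the carboxylic acid at the end of that chain.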